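Fluoro Added to the Pyridine Amide of Compound 2

The compounds below may be only part of what the source reports. "The series", "measured", "known", "first", "only" and "open" are said of these compounds alone.

Compound 1 `COc1cccc(NC(=O)COc2ccc3cc(/C=C4/SC(=O)NC4=O)ccc3c2)c1` gives 7600 nM in an assay on isolated protein for inhibition of histone deacetylase 8 (Homo sapiens), with a stated time of 1 h; on this read-out lower numbers stand for stronger inhibition and higher numbers for weaker inhibition. Compound 2 `O=C(COc1ccc2cc(/C=C3/SC(=O)NC3=O)ccc2c1)Nc1ccccn1` reaches only a limit in this assay, > 50000 nM, and so stands at the weak end of the two numbers shown, as the limit of > 50000 nM in this assay, at which 1 of the 2 values shown sits, records. For the measured compounds named here, the single measured step, an at least 6.5-fold higher number from compound 1 to compound 2 (0.81 log units; beyond the scatter), concerns the pyridin-2-yl amide itself and says nothing about a fluoro change. Compound 3 `O=C(COc1ccc2cc(/C=C3/SC(=O)NC3=O)ccc2c1)Nc1cccc(F)n1` differs from compound 2 by fluoro in place of hydrogen on an aromatic carbon. Compound 3 is expected to remain near that limit, a step of a number no higher from compound 2 to compound 3 (the limit leaves the size open). Compound 3 is therefore estimated at 50000 nM, within 15000 nM to 150000 nM.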

Compound 3, half-maximal inhibitory concentration: 7200 nM
The estimate for compound 3 lay 6.9-fold (0.84 log units) above the measured number; measured number outside the range, below it.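

In this assay, this position next to the ring nitrogen proves sensitive to a single fluoro, with an at least 6.9-fold lower number from compound 2 to compound 3 (0.84 log units; beyond the scatter). The 6-fluoropyridin-2-yl amide also matches the 3-methoxyphenyl amide, with a 1.1-fold lower number from compound 1 to compound 3 (0.02 log units; within the scatter), so a pyridine amide need not lie at the weak end. The true size of the fluoro step stays open because compound 2 is recorded only as a limit: the limit of > 50000 nM in this assay, at which 1 of the 3 values shown sits.

On these data alone, whether chloro, methyl or an amine at this same place would act as fluoro does remains open. So does whether fluoro elsewhere on the pyridine would give a similar step.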